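The source may report more compounds than this note shows. Statements on the series, on what has been measured and on what is new or still open speak of the compounds shown alone.

Compound 1 `C=CC[C@@H]1O[C@H](COCc2ccccc2)[C@@H](OCc2ccccc2)[C@H](OCc2ccccc2)[C@H]1O`: 15100 nM
Compound 2 `CC[C@@H]1O[C@H](COCc2ccccc2)[C@@H](OCc2ccccc2)[C@H](OCc2ccccc2)[C@H]1O`: 8200 nM

In a functional assay on HL-60 cells (Homo sapiens) for antiproliferative activity, read by MTT assay (on this read-out higher numbers stand for weaker inhibition and lower numbers for stronger inhibition), compound 2 gives 8200 nM. Going by the values given here, with only two numbers available, compound 2 cannot be separated from compound 1, as the step between them is a 1.8-fold lower number from compound 1 to compound 2 (0.27 log units; within the scatter).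

Compound 3 `CCC[C@@H]1O[C@H](COCc2ccccc2)[C@@H](OCc2ccccc2)[C@H](OCc2ccccc2)[C@H]1O` has not yet been measured. Its change from compound 2 is methyl in place of hydrogen on a saturated chain carbon, two bonds along the chain from a saturated ring carbon. This extends ethyl to propyl.

Among the compounds with values here, one measured step bears on this change, though only indirectly, since it concerns a different replacement in the same chain: a 1.8-fold lower number from compound 1 to compound 2 (0.27 log units; within the scatter). Within the data shown here, no measured step shows a change beyond the scatter, so no direction can be assigned. The expected step is a 1.2-fold higher number from compound 2 to compound 3 (0.09 log units; within the scatter), which means none beyond the scatter.

The estimate for compound 3 is 10000 nM, with an expected range of 5000 nM to 20000 nM.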

Compound 3, half-maximal inhibitory concentration: 11700 nM
Compound 3: the middle estimate sits 1.2-fold (0.07 log units) below what was measured; the measured number falls inside the stated range.
By their numbers in this assay, from the lowest: compounds 2, 3 and 1 (each within the scatter of the next).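

In this assay, the series now has three chains at this position, and methyl in place of hydrogen on a saturated chain carbon, two bonds along the chain from a saturated ring carbon, gives a 1.4-fold higher number from compound 2 to compound 3 (0.15 log units; within the scatter) within the scatter. The remaining step, a 1.3-fold lower number from compound 1 to compound 3 (0.11 log units; within the scatter), is also within the scatter, so compounds 1, 2 and 3 cannot be separated on this read-out. No supporting evidence bears on this result.

The compounds shown leave open whether a longer chain, such as hexyl, or a chain ending in an amine or a carboxylic acid would give a step beyond the scatter. They also leave open whether replacing a benzyl ether on the shared core would do so.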